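This account rests on a few compounds, and the source may have more. Where it says the series, first, only, none or still open, it means among the compounds named here.

Among the compounds with values here, in an ADME assay on the whole organism (Mus musculus, strain C57BL6/N) for pharmacokinetics, read by LC-MS, with a stated time of 24 h, at a dose of 1 mg/kg by the intravenous route (a higher number here means faster removal of the compound, a lower number slower removal), compound 1 (`Cc1c(C(N)=O)cnc2c1CCN2`) gives 182 mL/min/kg and compound 2 (`NC(=O)c1cnc2c(c1Cl)CCN2`) gives 179 mL/min/kg so compound 1 stands level with the only other measured compound, within the scatter. That single measured step (a 1.0-fold lower number from compound 1 to compound 2 (0.01 log units; within the scatter)) is chloro in place of methyl on an aromatic carbon. Compound 3 (`Cc1c(C(N)=O)cnc2c1C[C@@H](C)N2`) differs from compound 1 by methyl in place of hydrogen on a saturated ring carbon. Within the data shown here, the measured step concerns an aromatic carbon and not the saturated ring carbon, so it bears on this change only indirectly, and no measured compound carries a group at the new place. With so little to go on, no step beyond the scatter is expected (a 1.2-fold lower number from compound 1 to compound 3 (0.08 log units; within the scatter)). The estimated clearance for compound 3 is 150 mL/min/kg (estimated range 80 mL/min/kg to 230 mL/min/kg).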

Compound 3, clearance: 90 mL/min/kg
Compound 3: the middle estimate sits 1.7-fold (0.22 log units) above what was measured; the range from low to high includes it.
By their numbers in this assay, from the lowest: compounds 3, 2 and 1 (each within the scatter of the next, the first and the last beyond it).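

In this assay, within the data shown here, the methyl on a saturated ring carbon, next to the ring nitrogen, brings a 2.0-fold lower number from compound 1 to compound 3 (0.31 log units; beyond the scatter) and so gives the first step beyond the scatter. The earlier step, a 1.0-fold lower number from compound 1 to compound 2 (0.01 log units; within the scatter), concerned an aromatic carbon and showed no change, whereas this saturated ring carbon responds to a single added methyl, though the step is modest and rests on one pair. No measurement at hand explains why clearance falls with this change.

Going by these compounds, whether an ethyl, a hydroxyl or a second methyl on the same carbon would lower clearance further remains open, as does the effect of the opposite arrangement of the methyl at this carbon. Also open, on these data alone, is whether the step holds when chloro replaces the aromatic methyl.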